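Working notes on compound 3 and its expected potency

The source may report more compounds than this note shows. Statements on the series, on what has been measured and on what is new or still open speak of the compounds shown alone.

Measured so far:
compound 1 `O=C(Nc1cccc(-c2nc(-c3ccc(NC(=O)c4cccnc4)cc3Cl)no2)c1)Nc1ccc(Cl)c(C(F)(F)F)c1` — 1900 nM
compound 2 `CS(=O)(=O)Nc1ccc(NC(=O)Nc2cccc(-c3nc(-c4ccc(NC(=O)c5cccnc5)cc4Cl)no3)c2)cc1C(F)(F)F` — 700 nM

In a functional assay on MDA-MB-231 cells (Homo sapiens) for antiproliferative activity, read by MTT assay, with a stated time of 72 h (on this read-out lower numbers stand for stronger inhibition and higher numbers for weaker inhibition), compound 2 gives the lowest of the two numbers; compound 1 stands nearest, a 2.7-fold lower number from compound 1 to compound 2 (0.43 log units; beyond the scatter). Compound 3 `O=C(Nc1cccc(-c2nc(-c3ccc(NC(=O)c4cccnc4)cc3Cl)no2)c1)Nc1ccc(NC(=O)c2cccs2)c(C(F)(F)F)c1` differs from compound 2 by (thiophen-2-yl)carbonyl in place of methylsulfonyl on a nitrogen on an aromatic ring. Going by the values given here, only the step from compound 1 to compound 2 touches this part of the molecule, and it was modest; no measured step replaces methylsulfonyl by an acyl group, so the direction is open. The expectation is a change within the scatter, a 1.3-fold higher number from compound 2 to compound 3 (0.11 log units; within the scatter). For compound 3 the estimated value in this assay is 900 nM, within 300 nM to 2500 nM.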

Compound 3, half-maximal inhibitory concentration: 2900 nM
Beside the measured number, compound 3's estimate is 3.2-fold (0.51 log units) below it; the measured number lies above the stated range.
By their numbers in this assay, from the lowest: compound 2; then compounds 1 and 3 (each within the scatter of the next).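

In this assay, the step of a 4.1-fold higher number from compound 2 to compound 3 (0.62 log units; beyond the scatter) shows that the result at this nitrogen depends on the group attached: (thiophen-2-yl)carbonyl does not hold the level reached with methylsulfonyl. The step of a 1.5-fold higher number from compound 1 to compound 3 (0.18 log units; within the scatter) leaves ((thiophen-2-yl)carbonyl)amino and chloro on this aromatic carbon indistinguishable, so the gain seen with methanesulfonamido is not shared by this amide. No evidence on the compounds shown accounts for the difference between the two groups. Open, from the compounds shown here alone, is whether a plain acetyl on the same nitrogen tracks compound 3 or compound 2, and where a free amine on this aromatic carbon would fall.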